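Swapping the group on a ring nitrogen

The source may report more compounds than this note shows. Statements on the series, on what has been measured and on what is new or still open speak of the compounds shown alone.

Three compounds share one core and differ only in the group on an amine nitrogen in a ring. In an ADME assay on L6 cells (Rattus norvegicus) for cytotoxicity (a lower number here means a stronger inhibitor, a higher number a weaker inhibitor), compound 1 `COc1ccc(N2CCN(C(=O)Cn3cnc([N+](=O)[O-])n3)CC2)cc1` gives 133000 nM, compound 2 `O=C(Cn1cnc([N+](=O)[O-])n1)N1CCN(c2ccccn2)CC1` gives 173000 nM, and compound 3 `O=C(Cn1cnc([N+](=O)[O-])n1)N1CCN(c2ccc(Cl)c(Cl)c2)CC1` gives 108000 nM. Compound 3 therefore stands within the scatter of both others, and the three cannot be ranked.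

Compound 4 `O=C(Cn1cnc([N+](=O)[O-])n1)N1CCN(C(=O)C2CC2)CC1` has cyclopropylcarbonyl in place of 3,4-dichlorophenyl on that nitrogen: cyclopropylcarbonyl in place of 3,4-dichlorophenyl on an amine nitrogen in a ring.

Within the data shown here, three measured steps bear on this change: a 1.3-fold higher number from compound 1 to compound 2 (0.11 log units; within the scatter), a 1.2-fold lower number from compound 1 to compound 3 (0.09 log units; within the scatter) and a 1.6-fold lower number from compound 2 to compound 3 (0.20 log units; within the scatter). All three stay within the scatter, but each exchanges one six-membered aromatic ring for another. The entering group has no aromatic ring, so these steps are only a loose guide. On that evidence, no step beyond the scatter is expected in this assay. The estimated move, a 1.4-fold higher number from compound 3 to compound 4 (0.14 log units; within the scatter), is expected to be small. Compound 4 is expected at 150000 nM, with an estimated range of 75000 nM to 300000 nM.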

Compound 4, half-maximal inhibitory concentration: 156000 nM
Compound 4: the middle estimate sits 1.0-fold (0.02 log units) below what was measured; the range from low to high includes it.
By their numbers in this assay, from the lowest: compounds 3, 1, 4 and 2 (each within the scatter of the next).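

Until now every group on this nitrogen carried a six-membered aromatic ring, whereas cyclopropylcarbonyl has a three-membered non-aromatic ring and a carbonyl. Even so, all three new steps in this assay stay small (a 1.4-fold higher number from compound 3 to compound 4 (0.16 log units; within the scatter)) (a 1.1-fold lower number from compound 2 to compound 4 (0.04 log units; within the scatter)) (a 1.2-fold higher number from compound 1 to compound 4 (0.07 log units; within the scatter)), so across these four compounds an aromatic ring on this nitrogen is not required to keep the number in the same range. Nothing measured here accounts for this lack of change.

All four compounds lie within the scatter of one another, so none of the groups shown reveals what could move the number at this position. From the compounds shown here alone, whether a carboxylic acid, an amine or a longer chain on this nitrogen would produce a step beyond the scatter remains open.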